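Swapping Bromo for Methylsulfanyl on a Receptor Binder

A few compounds are considered here, and "the series" means these few. Any claim that something is new, unique, unknown or untested is made for them only; others in the source may bear on it.

Compound 1 `CCN(c1nc(C)cc(C)n1)c1ccc(OC)cc1Br` gives 35 nM in an assay on isolated protein for binding affinity to corticotropin-releasing factor receptor 1 (Homo sapiens) (a lower number here means a stronger inhibitor, a higher number a weaker inhibitor), the higher of the two plain numbers shown. Compound 2 `CCN(c1nc(C)cc(C)n1)c1c(Br)cc(OC)cc1OC` gives 12 nM. Compound 3 `CCN(c1nc(C)cc(C)n1)c1ccccc1Br` reports > 1000 nM, which is a limit of the assay rather than a number (the limit of > 1000 nM in this assay, at which 1 of the 3 values shown sits). The change toward compound 4 `CCN(c1nc(C)cc(C)n1)c1ccc(OC)cc1SC` is methylsulfanyl in place of bromo on an aromatic carbon. Neither measured step touches the bromo group: a 2.9-fold lower number from compound 1 to compound 2 (0.46 log units; beyond the scatter) is a modest gain, and an at least 28-fold higher number from compound 1 to compound 3 (1.45 log units; beyond the scatter) is a large loss, yet both concern a methoxy group and so give no direct guide here. The bromo-to-methylsulfanyl swap is therefore expected to shift the number little, within or only slightly beyond the scatter. Compound 4 is estimated at 50 nM, ranging from 15 nM to 170 nM, meaning an expected 1.4-fold higher number from compound 1 to compound 4 (0.15 log units; within the scatter).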

Compound 4, inhibition constant: 60 nM
The estimate for compound 4 lay 1.2-fold (0.08 log units) below the measured number, within the range that was stated.
By their numbers in this assay, from the lowest: compound 2; then compounds 1 and 4 (each within the scatter of the next). At a limit, above all of these: compound 3.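

For the compounds shown here, all the earlier compounds carried bromo at this position, ortho to a large group, so they could not show whether another group can stand there. In this assay the swap gives a 1.7-fold higher number from compound 1 to compound 4 (0.23 log units; within the scatter) and thus no real difference, so methylsulfanyl, with its two heavy atoms and one hydrogen-bond acceptor, serves here as well as bromo. From the compounds shown here alone, how an amine, a hydroxyl group or a longer sulfur-bearing chain would fare at this position remains open, as does whether the extra methoxy group of compound 2 would act the same alongside methylsulfanyl. Nothing shown gives a reason why the two groups match.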